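The source may hold more compounds than are shown below. What is called first, only, known or untested is meant among the compounds shown, and "the series" means these compounds.

Measured in a functional assay on MCF7 cells (Homo sapiens) for antiproliferative activity, read by MTT assay, with a stated time of 72 h; a lower number here means a stronger inhibitor, a higher number a weaker inhibitor:
- compound 1 `CCC/C=C/C(=O)Nc1cccc(Oc2nc(Nc3ccn(C)n3)nc3c2CSCC3)c1`: 22600 nM
- compound 2 `C/C=C/C(=O)Nc1cccc(Oc2nc(Nc3cccc(OC)c3)nc3c2CSCC3)c1`: 23400 nM

On these numbers, compound 2 at 23400 nM lies within the usual scatter of compound 1 at 22600 nM, so the two cannot be ranked.

Compound 3 `CCC/C=C/C(=O)Nc1cccc(Oc2nc(Nc3cccc(OC)c3)nc3c2CSCC3)c1` has not yet been measured. It differs from compound 2 by one change, (ethyl in place of hydrogen on a saturated chain carbon bound to a double-bonded chain carbon), which turns prop-1-en-1-yl into pent-1-en-1-yl. Among the measured compounds shown here, no measured pair shows this change on its own, so the data give no direct size for it in this assay. Compound 1 already carries the pent-1-en-1-yl group and gives 22600 nM, which offers a modest reason to expect no step beyond the scatter in either direction. The expected 1.1-fold lower number from compound 2 to compound 3 (0.05 log units; within the scatter) is therefore small. The estimated value for compound 3 is 21000 nM, with an expected range from 10000 nM to 42000 nM.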

Compound 3, half-maximal inhibitory concentration: 32000 nM
Compound 3: the middle estimate sits 1.5-fold (0.18 log units) below what was measured; measured number inside the range.
By their numbers in this assay, from the lowest: compounds 1, 2 and 3 (each within the scatter of the next).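

In this assay the change from prop-1-en-1-yl to pent-1-en-1-yl now has a direct reading, a 1.4-fold higher number from compound 2 to compound 3 (0.14 log units; within the scatter) and so no effect of this ethyl on a saturated chain carbon bound to a double-bonded chain carbon can be told apart from the ordinary spread of repeated measurements. Among the compounds shown here, compound 3 also gives the first direct reading for the group on the nitrogen: 3-methoxyphenyl in place of 1-methyl-1H-pyrazol-3-yl gives a 1.4-fold higher number from compound 1 to compound 3 (0.15 log units; within the scatter) and that step cannot be told from the spread either. Across these three compounds, neither change moves the number beyond the scatter.

On these data alone, whether an amine, a carboxylic acid or a much longer chain in place of this ethyl would shift the number remains open. No further measurement bears on why the numbers sit where they do.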